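The source may hold more compounds than are shown below. What is called first, only, known or untested is meant among the compounds shown, and "the series" means these compounds.

Working notes on the series.

Compound 1 `CC(C)NC(=O)CC(c1ccc(-c2ccc3cccc(F)c3c2)[nH]c1=O)C(C)C` is the reference for this step. Within the data shown here, in a functional assay on CHO cells for antagonist activity at prostaglandin E2 receptor EP3 subtype (Homo sapiens), read by cAMP accumulation (a higher number here means a weaker inhibitor, a lower number a stronger inhibitor), compound 1 gives 15 nM, which is the second highest of the three numbers so far. Compound 2 `CC(C)C(Nc1nccs1)c1ccc(-c2ccc3cccc(F)c3c2)[nH]c1=O` gives 10 nM in this assay, and compound 3 `CC(C)C(c1ncco1)c1ccc(-c2ccc3cccc(F)c3c2)[nH]c1=O` gives 64 nM. The step of a 1.5-fold lower number from compound 1 to compound 2 (0.18 log units; within the scatter) is within the scatter, whereas a 4.3-fold higher number from compound 1 to compound 3 (0.63 log units; beyond the scatter) and a 6.4-fold higher number from compound 2 to compound 3 (0.81 log units; beyond the scatter) are both modest but beyond it.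

Compound 4 `CC(C)C(c1cnc(N)s1)c1ccc(-c2ccc3cccc(F)c3c2)[nH]c1=O` differs from compound 1 as follows: 2-amino-1,3-thiazol-5-yl in place of (isopropylcarbamoyl)methyl on a saturated chain carbon bound to an aromatic carbon and a saturated chain carbon. The two steps that bear on this change are the replacement by (1,3-thiazol-2-yl)amino, which left the number essentially unchanged, and the replacement by 1,3-oxazol-2-yl, which raised it. Compound 4 carries a five-membered aromatic ring with 2 hetero atoms bound directly to the chain carbon, as in compound 3, but also a hydrogen-bond donor, as in compound 2. A small to modest rise in the number is therefore expected for compound 4, placed between the outcomes of compound 2 and compound 3.

Compound 4 is expected to give 30 nM in this assay, with a range of 10 nM to 90 nM. This corresponds to an expected step of a 2.0-fold higher number from compound 1 to compound 4 (0.30 log units; within the scatter).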

Compound 4, half-maximal inhibitory concentration: 39 nM
The estimate for compound 4 lay 1.3-fold (0.11 log units) below the measured number; low and high end bracket the measured number.
By their numbers in this assay, from the lowest: compounds 2 and 1 (each within the scatter of the next); then compounds 4 and 3 (each within the scatter of the next).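

In this assay, placing 2-amino-1,3-thiazol-5-yl on this saturated chain carbon gives a 2.6-fold higher number from compound 1 to compound 4 (0.41 log units; beyond the scatter) and a 3.9-fold higher number from compound 2 to compound 4 (0.59 log units; beyond the scatter), so this directly bound ring with its amino group does not reproduce the result of the (1,3-thiazol-2-yl)amino group. Against the other directly bound ring, the change gives a 1.6-fold lower number from compound 3 to compound 4 (0.22 log units; within the scatter), so 2-amino-1,3-thiazol-5-yl and 1,3-oxazol-2-yl cannot be told apart at this position in this assay. No measured evidence accounts for these differences.

The compounds shown do not separate the contribution of the amino group from that of the ring carrying it. An unsubstituted 1,3-thiazol-5-yl group, or a methylamino group in place of the amino group on that ring, would address this question.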